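A few compounds are considered here, and "the series" means these few. Any claim that something is new, unique, unknown or untested is made for them only; others in the source may bear on it.

Of the compounds shown here, three have been measured in an assay on HeLa cells for displacement of a labelled ligand from adenosine receptor A3 (Homo sapiens), read by scintillation counting, with a stated time of 180 min, tested at 10 uM; a lower number here means less inhibition, a higher number more inhibition at the concentration tested (going by the name of the read-out). Compound 1, `N=c1oc2ccc(Br)cc2cc1C(=O)NC1CCCCC1`, gives 8%. Compound 2, `O=C(O)CNC(=O)c1cc2ccccc2oc1=O`, gives 0%, and compound 3, `COCCNC(=O)c1cc2cccc(OC)c2oc1=N`, gives 15%. All three numbers lie within the usual scatter of one another, so compound 1 cannot be told apart from compound 2 or from compound 3 on these numbers, and none of the three displaces much of the labelled ligand at the concentration used.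

Compound 4, `CCC(CO)NC(=O)c1cc2cc(Br)ccc2oc1=N`, has not yet been measured. It differs from compound 1 in a single place: 1-(hydroxymethyl)propyl in place of cyclohexyl on an amide-type nitrogen. The carbonyl carbon that is the other neighbour of that amide-type nitrogen is unchanged, as is the rest of the shared core. Among the measured compounds shown here, no two measured compounds differ in only one place, so there is no measured step of this kind to lean on.

Because compound 1 gives only 8% in this assay , and compounds 2 and 3 stay within the scatter of that number, the estimate for compound 4 is 10%, with a range from 0% to 25%. For compound 4 the expected step is a number 2 percentage points higher from compound 1 to compound 4 (within the scatter), which is no more than the scatter in either direction.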

Compound 4, a percentage reported as inhibition, at one concentration (the size of the read-out at that concentration, not a potency): 24%
Compound 4: middle estimate off by 14 percentage points, on the low side; low and high end bracket the measured number.
By their numbers in this assay, from the lowest: compounds 2, 1, 3 and 4 (each within the scatter of the next, the first and the last beyond it).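

In this assay, among the compounds shown here, this is the first single change whose effect can be read: with 1-(hydroxymethyl)propyl in place of cyclohexyl on the amide-type nitrogen, the read-out shows a number 16 percentage points higher from compound 1 to compound 4 (beyond the scatter). The step shows that the group at this position can shift the read-out while the rest of the shared core stays the same, and that the six-membered carbon ring is not needed to keep the inhibition seen with compound 1; even so, the step is modest, and compound 4 gives 24% at a single concentration, which is not a measure of potency. Nothing measured here explains why the number moves.

The swap removes a ring and adds a hydroxyl-bearing open chain in one move, so the compounds shown cannot say which of these two differences carries the step. A plain butyl group on the same nitrogen would test the open chain without its oxygen, and an amine in place of the hydroxyl would test whether that oxygen can be replaced.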